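This account rests on a few compounds, and the source may have more. Where it says the series, first, only, none or still open, it means among the compounds named here.

Compound 1, with the structure `O=C(O)CC(Cc1nc2cc(Cl)ccc2[nH]1)c1ccc(Cl)cc1`, gives 70% in an assay on isolated protein for inhibition of protein kinase C zeta type (Homo sapiens), read by 33P incorporation, tested at 200 uM; a higher number here means a stronger effect of the compound at the concentration tested, a lower number a weaker effect. Among the measured compounds shown here, that is the higher of the two numbers measured so far; its nearest neighbour is compound 2, `CCc1ccc2[nH]c(CC(CC(=O)O)c3ccc(Cl)cc3)nc2c1`, which in this assay gives 0%. For the measured compounds named here, the single measured step that connects the two, a number 70 percentage points lower from compound 1 to compound 2 (beyond the scatter), removes almost the whole effect seen for compound 1.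

Compound 3, `N#Cc1ccc2[nH]c(CC(CC(=O)O)c3ccc(Cl)cc3)nc2c1`, is the compound now in question. It differs from compound 1 in one place: cyano in place of chloro on an aromatic carbon. Going by the values given here, the step from compound 1 to compound 2 is the only measured step that bears on it, since it replaces the same chloro on the shared core, but what enters there is an ethyl rather than a cyano, so it shows only that a change at this point can cost a great deal. Nothing measured speaks to a cyano group directly, so the expectation is a loss of uncertain size, with wide uncertainty. The step expected here is a number 40 percentage points lower from compound 1 to compound 3 (beyond the scatter). For compound 3 the estimated value is 30%, with a range from 0% to 70%.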

Compound 3, a percentage reported as inhibition, at one concentration (the size of the read-out at that concentration, not a potency): 0%
For compound 3 the middle estimate is 30 percentage points above the measured one; measured number inside the range.
By their numbers in this assay, from the lowest: compounds 2 and 3 (each within the scatter of the next); then compound 1.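

The cyano group does no better at this carbon than the ethyl group did: putting it in place of the chloro gives a number 70 percentage points lower from compound 1 to compound 3 (beyond the scatter) in this assay, so the earlier loss was not peculiar to ethyl. Exchanging one of these groups for the other gives no change at the digits printed from compound 2 to compound 3 (within the scatter), and since both compounds sit at the bottom of the read-out, this assay at its single tested concentration does not separate them. Among the three compounds shown, then, the effect appears only with the chloro on this aromatic carbon, and two quite different replacements both remove it entirely, though no measurement here explains why.

On these data alone, what stays open is whether the effect depends on chloro in particular or would survive other replacements at this carbon, a question that a bromo, a fluoro, a methyl or a plain hydrogen there could begin to answer. It is also unknown whether a methoxy or an amine would fall to the same bottom reading, or whether any group here could match or pass compound 1.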